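The compounds below may be only part of what the source reports. "The series", "measured", "known", "first", "only" and "open" are said of these compounds alone.

In a functional assay on A549 cells (Homo sapiens) for cytotoxicity, read by MTT assay, with a stated time of 72 h (on this read-out higher numbers stand for weaker inhibition and lower numbers for stronger inhibition), compound 1 (`CCc1ccc(-c2cc(C(=O)Nc3ccc(Oc4ccnc(C(=O)NC)c4)cc3)ncn2)cc1`) gives 13300 nM, the higher of the two numbers in the series, and compound 3 (`CCc1ccc(-c2cc(C(=O)Nc3ccc(Oc4ccnc(C(=O)NC)c4)c(F)c3)ncn2)cc1`) gives 3390 nM. For compound 2 (`CNC(=O)c1cc(Oc2ccc(NC(=O)c3nccc(-c4ccc([N+](=O)[O-])cc4)n3)cc2)ccn1`) the assay reports only a limit, > 100000 nM. Compound 4 (`CNC(=O)c1cc(Oc2ccc(NC(=O)c3cc(-c4ccc(F)cc4)ncn3)cc2)ccn1`) differs from compound 1 in one place: fluoro in place of ethyl on an aromatic carbon, para to a large group. For the measured compounds named here, the one measured step that bears on this is a 3.9-fold lower number from compound 1 to compound 3 (0.59 log units; beyond the scatter), where fluoro replaces hydrogen rather than ethyl. Going by the values given here, no measured step removes the ethyl, so no step beyond the scatter is expected in this assay, and no direction is favoured with confidence. The expected change is a 1.2-fold higher number from compound 1 to compound 4 (0.08 log units; within the scatter). For compound 4 the estimate is 16000 nM, with an expected range of 4000 nM to 60000 nM.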

Compound 4, half-maximal inhibitory concentration: > 100000 nM
Compound 4: only a limit was reported (the forecaster's own chance of this, stated with the estimate: 12%); at least 6.2-fold (0.79 log units) between middle value and limit.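

Fluoro in place of ethyl on this aromatic carbon is not a neutral change in this assay: the step reads an at least 7.5-fold higher number from compound 1 to compound 4 (0.87 log units; beyond the scatter). It runs opposite to a 3.9-fold lower number from compound 1 to compound 3 (0.59 log units; beyond the scatter), which is a different change in a different place, so a fluoro swap has no single direction in this series. For compound 4, > 100000 nM is a limit, so the full size of the step stays unknown, and the limit is shared within the series: the limit of > 100000 nM in this assay, at which 2 of the 4 values shown sit.

On these data alone, it remains open whether ethyl itself matters or whether other groups at this carbon would serve equally well. A propyl chain, a methoxy or an amine in place of ethyl would bear on this.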